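Swapping the Halogenated Aryl Group of Compound 1

The compounds below may be only part of what the source reports. "The series", "measured", "known", "first", "only" and "open" are said of these compounds alone.

Measured so far:
compound 1 `COc1ccc2cc(C(C)c3nnc4n3N=C(c3ccc(Cl)cc3Cl)CS4)ccc2c1` — 14600 nM
compound 2 `CC(c1ccc(-c2ccccc2)c(F)c1)c1nnc2n1N=C(c1ccc(C(F)(F)F)cc1)CS2` — 4300 nM

In a functional assay on MCF7 cells (Homo sapiens) for inhibition, read by sulforhodamine B assay, with a stated time of 72 h (a lower number here means a stronger inhibitor, a higher number a weaker inhibitor), compound 1 gives 14600 nM, the highest of the two numbers; compound 2 gives 4300 nM, lower by a margin beyond the usual scatter. Compound 3 `COc1ccc2cc(C(C)c3nnc4n3N=C(c3ccc(Br)cc3)CS4)ccc2c1` is not yet measured. It differs from compound 1 in one place: 4-bromophenyl in place of 2,4-dichlorophenyl on a carbon with a double bond to nitrogen. For the measured compounds named here, no measured pair isolates this change, so the expectation rests on compound 1 alone. The step of a 1.5-fold lower number from compound 1 to compound 3 (0.16 log units; within the scatter) is expected to be small, leaning toward a lower number but likely within the scatter. Compound 3 is therefore estimated at 10000 nM, within 3500 nM to 30000 nM.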

Compound 3, half-maximal inhibitory concentration: 11500 nM
Beside the measured number, compound 3's estimate is 1.2-fold (0.06 log units) below it; low and high end bracket the measured number.
By their numbers in this assay, from the lowest: compound 2; then compounds 3 and 1 (each within the scatter of the next).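

In this assay, for the compounds shown here, the only step read at this position, a 1.3-fold lower number from compound 1 to compound 3 (0.10 log units; within the scatter), shows that 4-bromophenyl can take the place of 2,4-dichlorophenyl on the carbon with a double bond to nitrogen without a change beyond the scatter. The two aryl groups therefore cannot be told apart in this read-out, on the core of compound 1. No measurement given here explains this result. Still open, from the compounds shown here alone, is whether an unsubstituted phenyl, a pyridine ring or an aryl group carrying a carboxylic acid or an amine at this position would move the number beyond the scatter.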